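The compounds below may be only part of what the source reports. "The series", "measured", "known", "first", "only" and "open" are said of these compounds alone.

The measured compounds:
- Compound 1, `Cc1nc(Nc2ccc(Cl)cc2)sc1C(=O)/C=C/c1ccccc1`; in a functional assay on BGC-823 cells (Homo sapiens) for cytotoxicity, read by MTT assay (a lower number here means a stronger inhibitor, a higher number a weaker inhibitor), compound 1 gives > 25000 nM, which is a limit of the assay.
- Compound 2, `Cc1nc(Nc2ccccc2)sc1C(=O)/C=C/c1ccccc1`; in this assay compound 2 gives 19500 nM.
- Compound 3, `Cc1ccc(Nc2nc(C)c(C(=O)/C=C/c3ccccc3Cl)s2)cc1`; in this assay compound 3 gives > 25000 nM, which is a limit of the assay.

Compound 3 therefore stands at the limit of this assay rather than at a number, and it shares that position with another of the three values shown, namely (the limit of > 25000 nM in this assay, at which 2 of the 3 values shown sit). Compound 4, `Cc1ccc(Nc2nc(C)c(C(=O)/C=C/c3ccccc3)s2)cc1`, differs from compound 3 by hydrogen in place of chloro on an aromatic carbon. Among the compounds with values here, the only measured step of the same kind is an at least 1.2-fold lower number from compound 1 to compound 2 (0.10 log units; that floor lies within the scatter), which removes a chloro group on a different ring of the shared core and moves from a limit to a number at a floor that lies within the scatter. Within the data shown here, no step on the ring changed here has been measured. On that basis no step beyond the scatter is expected, and a step that the limit leaves unreadable from compound 3 to compound 4 is the estimated size of the change. Compound 4 is estimated at 30000 nM in this assay, with a range from 12000 nM to 80000 nM, and a limit rather than a number is again a likely outcome.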

Compound 4, half-maximal inhibitory concentration: > 25000 nM
Compound 4 ended at the assay's limit; the forecaster's own chance of this, stated with the estimate: 60%; the middle value does not contradict the limit.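

In this assay, the change from 2-chlorophenyl to phenyl leaves compound 4 at a limit of the assay, as compound 3 was, so the steps to compound 4 from compound 3 and from compound 1 cannot be read. Within the data shown here, the one readable step is of a new kind, methyl in place of hydrogen on an aromatic carbon: an at least 1.2-fold higher number from compound 2 to compound 4 (0.10 log units; that floor lies within the scatter), a floor that leaves the true size of the step open. Only compound 2 gives a number, and the rest sit at one limit: the limit of > 25000 nM in this assay, at which 3 of the 4 values shown sit.

The compounds shown leave open whether a methoxy group or a dimethylamino group in place of that chloro would give a number rather than a limit. The same question stands for a hydroxyl group in place of the methyl of compound 4.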